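This account rests on a few compounds, and the source may have more. Where it says the series, first, only, none or still open, it means among the compounds named here.

Compound 1 `Cc1cc(NC(=O)Nc2ccccc2OC(F)(F)F)c2ccccc2n1` bears a trifluoromethoxy group on a six-membered aromatic ring of carbon only. In an ADME assay on Raji cells (Homo sapiens) for cytotoxicity, with a stated time of 72 h (a lower number here means that less compound is needed, a higher number that more compound is needed for the effect), compound 1 gives > 25000 nM, which is a limit of the assay rather than a number. Compound 2 `Cc1cc(NC(=O)Nc2cccc(C(C)(C)C)c2)c2ccccc2n1` also reaches only a limit in this assay, at > 25000 nM. Compound 3 `Cc1cc(NC(=O)Nc2cc(F)cc(F)c2)c2ccccc2n1` likewise shows a limit in this assay, at > 25000 nM. Every value shown thus sits at the limit of > 25000 nM in this assay, at which 3 of the 3 values shown sit, and compound 1 stands with the rest at that limit. Compound 4 `Cc1cc(NC(=O)Nc2ccccc2C(C)(C)C)c2ccccc2n1` differs from compound 1 by tert-butyl in place of trifluoromethoxy on an aromatic carbon, on an aromatic carbon ortho to a large group. Going by the values given here, no step between measured compounds is available, and the expected step of a number no higher from compound 1 to compound 4 (the limit leaves the size open) is none beyond the usual scatter. Compound 4 is therefore expected to give about 25000 nM, within 8000 nM to 60000 nM, most likely again only as a limit.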

Compound 4, half-maximal effective concentration: > 25000 nM
Compound 4: no number, only a limit; the forecaster's own chance of this, stated with the estimate: 80%; the middle value sits exactly at the limit.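

In this assay, compound 1 and compound 4 each give only a limit, so no step between them can be read: the limit of > 25000 nM in this assay, at which 4 of the 4 values shown sit.

The compounds shown leave open whether tert-butyl and trifluoromethoxy differ at all in this assay.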